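A few compounds are considered here, and "the series" means these few. Any claim that something is new, unique, unknown or untested is made for them only; others in the source may bear on it.

Measured so far in an ADME assay on HCT-116 cells (Homo sapiens) for cytotoxicity, read by MTT assay, with a stated time of 72 h; a lower number here means a stronger inhibitor, a higher number a weaker inhibitor:

- compound 1 `CCOc1ccc(NC(=O)c2cccc(/C=C3\CC(=O)N(c4ccccc4)C3=O)c2)cc1`: in this assay compound 1 gives 84800 nM
- compound 2 `COc1ccc(OC)c(NC(=O)c2cccc(/C=C3\CC(=O)N(c4ccccc4)C3=O)c2)c1`: in this assay compound 2 reaches only the limit of the assay, > 100000 nM
- compound 3 `O=C(Nc1ccc(Cl)cc1)c1cccc(/C=C2\CC(=O)N(Cc3ccccc3)C2=O)c1`: in this assay compound 3 likewise reaches only the limit of the assay, > 100000 nM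

Compound 2 therefore stands not at a number but at the ceiling of this assay, the same ceiling that two of the three results share (the limit of > 100000 nM in this assay, at which 2 of the 3 values shown sit). Among the measured compounds shown here, the one measured step on the group carried by the amide-type nitrogen is an at least 1.1-fold higher number from compound 1 to compound 2 (0.07 log units; that floor lies within the scatter), a step that at its floor lies within the scatter and that ends at the limit rather than at a value.

Compound 4 `CSc1cccc(NC(=O)c2cccc(/C=C3\CC(=O)N(c4ccccc4)C3=O)c2)c1` is the next member. The change from compound 2 is 3-(methylsulfanyl)phenyl in place of 2,5-dimethoxyphenyl on an amide-type nitrogen.

For the measured compounds named here, only the step from compound 1 to compound 2 bears on a change at this position, and it was small and not resolved past the limit. Going by the values given here, no measured step points in either direction beyond the scatter. Compound 4 is therefore expected to sit near the same ceiling, with a number no higher from compound 2 to compound 4 (the limit leaves the size open) as the estimated step, and the expected value for compound 4 is 100000 nM, within 40000 nM to 250000 nM.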

Compound 4, half-maximal inhibitory concentration: 65200 nM
The estimate for compound 4 lay 1.5-fold (0.19 log units) above the measured number, and the stated range covers the measured number.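

In this assay the group on the amide-type nitrogen now gives a second number rather than a limit, so the exchange of 2,5-dimethoxyphenyl for 3-(methylsulfanyl)phenyl can be read as a floor: an at least 1.5-fold lower number from compound 2 to compound 4 (0.18 log units; that floor lies within the scatter). The two groups at this position that both carry numbers stay unresolved, with a 1.3-fold lower number from compound 1 to compound 4 (0.11 log units; within the scatter), so 3-(methylsulfanyl)phenyl and 4-ethoxyphenyl cannot be told apart in this read-out. The full size of the step from compound 2 remains unreadable because that compound carries only a limit, and it shares that ceiling with compound 3: the limit of > 100000 nM in this assay, at which 2 of the 4 values shown sit.

The compounds shown leave open whether any group on the amide-type nitrogen can move the number beyond the scatter, as every step at this position so far lies within it or has its floor there. A phenyl carrying an amine or a carboxylic acid in place of the methoxy, ethoxy and methylsulfanyl groups would test that question on the same core.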